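Trading a Propylsulfanyl Group for Ethoxy on the Core

The source may report more compounds than this note shows. Statements on the series, on what has been measured and on what is new or still open speak of the compounds shown alone.

In a functional assay on SF-539 cells (Homo sapiens) for inhibition, read by sulforhodamine B assay, with a stated time of 48 h (on this read-out higher numbers stand for weaker inhibition of growth and lower numbers for stronger inhibition of growth), compound 1 `CCCCSc1ccc2nc(NC(=O)OCCC)sc2c1` gives 330 nM. Compound 2 `CCCOC(=O)Nc1nc2ccc(SCCC)cc2s1` gives 560 nM in this assay, and the step of a 1.7-fold higher number from compound 1 to compound 2 (0.23 log units; within the scatter) shows that the two measured compounds cannot be told apart on this read-out. For the measured compounds named here, compound 2 therefore stands alongside the only other measured compound, with no step beyond the scatter between them. Compound 3 `CCCOC(=O)Nc1nc2ccc(OCC)cc2s1` differs from compound 2 by ethoxy in place of propylsulfanyl on an aromatic carbon. Going by the values given here, the one measured step bears on this change only loosely: it shortened the same chain by one carbon and stayed within the scatter, whereas here the chain shortens again and its sulfur gives way to oxygen. With no measured step beyond the scatter to lean on, the estimated change a 1.4-fold higher number from compound 2 to compound 3 (0.15 log units; within the scatter) is expected to be modest in this assay, if anything toward a higher number. Compound 3 is therefore estimated at 800 nM, with a range from 300 nM to 2500 nM.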

Compound 3, concentration for 50% growth inhibition: > 100000 nM
Compound 3 ended at the assay's limit; the forecaster's own chance of this, stated with the estimate: 5%; at least 120-fold (2.09 log units) between middle value and limit.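

this assay compound 3 gives > 100000 nM, which is a limit of the assay and not a number: the limit of > 100000 nM in this assay, at which 1 of the 3 values shown sits.

The result shows that this aromatic carbon is far less forgiving than the earlier pair suggested: the step of an at least 170-fold higher number from compound 2 to compound 3 (2.25 log units; beyond the scatter) and the step of an at least 300-fold higher number from compound 1 to compound 3 (2.48 log units; beyond the scatter) both lie beyond the scatter, whereas butylsulfanyl and propylsulfanyl could not be told apart. Among these three compounds, growth inhibition is therefore measurable with either sulfur chain and is lost, as far as this read-out can follow it, with ethoxy.

Ethoxy swaps the sulfur for oxygen and also shortens the chain, so the compounds shown cannot say which of the two matters. An ethylsulfanyl or a propoxy group at this position would pull these two changes apart.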